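The source may hold more compounds than are shown below. What is called first, only, known or untested is meant among the compounds shown, and "the series" means these compounds.

Compound 1 `O=C(CI)NCCCCCC(=O)NCCCCCCNc1ncnc2c1ncn2[C@@H]1O[C@H](COP(=O)(O)OP(=O)(O)OP(=O)(O)O)[C@@H](O)[C@H]1O` is one of two compounds with a reading so far. In an assay on isolated protein for inhibition of hexokinase-1 (Rattus norvegicus), with a stated time of 6 h, tested at 10 mM (a lower number here means less inhibition, a higher number more inhibition at the concentration tested (going by the name of the read-out)), compound 1 gives 0%. Compound 2 `CN(CCCCN(C)C(=O)CCCNc1ncnc2c1ncn2[C@@H]1O[C@H](COP(=O)(O)OP(=O)(O)OP(=O)(O)O)[C@@H](O)[C@H]1O)C(=O)CCCNC(=O)CI` is the other; in this assay compound 2 gives 0%, level with compound 1 within the usual scatter. Compound 3 `O=C(I)NCC(=O)NCCCCCCNc1ncnc2c1ncn2[C@@H]1O[C@H](COP(=O)(O)OP(=O)(O)OP(=O)(O)O)[C@@H](O)[C@H]1O` differs from compound 1 by a group of 4 heavy atoms (1 carbon, 1 nitrogen, 1 oxygen, 1 iodine; no ring) in place of a group of 9 heavy atoms (6 carbon, 1 nitrogen, 1 oxygen, 1 iodine; no ring), on a saturated chain carbon bound to a carbonyl carbon. Among the compounds with values here, no measured pair differing in one place exists to set the size of such a step, and both measured compounds show no inhibition, so no change at the digits printed from compound 1 to compound 3 (within the scatter) is expected to be flat, none beyond the scatter. Compound 3 is therefore estimated at 0%, within 0% to 10%.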

Compound 3, a percentage reported as inhibition, at one concentration (the size of the read-out at that concentration, not a potency): 0%
Compound 3: the middle estimate sits on the measured number at the digits printed; measured number inside the range.
By their numbers in this assay, from the lowest: compounds 1, 2 and 3 (each within the scatter of the next).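

Swapping the 4-(((iodomethyl)carbonyl)amino)butyl group for a group of 4 heavy atoms, on a saturated chain carbon bound to a carbonyl carbon, gives no change at the digits printed from compound 1 to compound 3 (within the scatter) in this assay and so brings out no inhibition. A much smaller group here leaves the reading where the larger one had it, so the size of this group makes no visible difference in this set. No measurement shown explains this result. With every reading at the same level, the compounds shown leave open whether this position can affect inhibition at all. On these data alone, whether an amine or a carboxylic acid in this place would give any inhibition also stays open.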